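Pyridine oxide in place of pyridone on the shared core

A few compounds are considered here, and "the series" means these few. Any claim that something is new, unique, unknown or untested is made for them only; others in the source may bear on it.

The study measured three compounds in an assay on CHO cells for displacement of a labelled ligand from Substance-P receptor (Homo sapiens), in the presence of a further agent that is not named here; on this read-out higher numbers stand for weaker inhibition and lower numbers for stronger inhibition. Compound 1 `C[C@@H](O[C@H]1CN2C(=O)C=C(c3ccc(NS(C)(=O)=O)cc3)CC2[C@@H]1c1ccc(F)cc1)c1cc(C(F)(F)F)cc(C(F)(F)F)c1` gives 54 nM. Compound 2 `C[C@@H](O[C@H]1CN2C(=O)C=C(c3cc[n+]([O-])cc3)CC2[C@@H]1c1ccc(F)cc1)c1cc(C(F)(F)F)cc(C(F)(F)F)c1` gives 2.1 nM. Compound 3 `C[C@@H](O[C@H]1CN2C(=O)C=C(c3cc[nH]c(=O)c3)CC2[C@@H]1c1ccc(F)cc1)c1cc(C(F)(F)F)cc(C(F)(F)F)c1` gives 3.9 nM, the second highest of the three numbers; its nearest neighbour is compound 2, with a 1.9-fold higher number from compound 2 to compound 3 (0.27 log units; within the scatter), and its furthest is compound 1, with a 14-fold lower number from compound 1 to compound 3 (1.14 log units; beyond the scatter).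

Compound 4 `C[C@@H](O[C@H]1CN2C(=O)C=C(c3ccc[n+]([O-])c3)CC2[C@@H]1c1ccc(F)cc1)c1cc(C(F)(F)F)cc(C(F)(F)F)c1` is not yet measured. It differs from compound 3 in one place: a group of 7 heavy atoms (5 carbon, 1 nitrogen, 1 oxygen; one six-membered aromatic ring with 1 hetero atom) in place of a group of 7 heavy atoms (5 carbon, 1 nitrogen, 1 oxygen; one six-membered aromatic ring with 1 hetero atom), on a double-bonded ring carbon; the two have the same atoms, joined differently. The step that bears most on this change is the one between the two measured groups of the same size on this position, which lies within the scatter, a 1.9-fold higher number from compound 2 to compound 3 (0.27 log units; within the scatter). Both of these groups stand far from compound 1, as a 26-fold lower number from compound 1 to compound 2 (1.41 log units; beyond the scatter) shows. The expected step is therefore none beyond the scatter, with compound 4 estimated close to compound 2 and compound 3, giving a 1.1-fold lower number from compound 3 to compound 4 (0.05 log units; within the scatter). Compound 4 is thus expected to give about 3.5 nM in this assay, with a range from 1.2 nM to 10 nM.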

Compound 4, half-maximal inhibitory concentration: 2.3 nM
Compound 4: the middle estimate sits 1.5-fold (0.18 log units) above what was measured; the measured number falls inside the stated range.
By their numbers in this assay, from the lowest: compounds 2, 4 and 3 (each within the scatter of the next); then compound 1.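

In this assay the group on the double-bonded ring carbon of the shared core can be joined differently without a step beyond the scatter: there is a 1.7-fold lower number from compound 3 to compound 4 (0.23 log units; within the scatter) and also a 1.1-fold higher number from compound 2 to compound 4 (0.04 log units; within the scatter) on this change. The group that leaves counts 1 hydrogen-bond donor and the group that enters counts 0, so the donor of compound 3 is not needed for a number in this range. A third group of this size now stands apart from the larger group of compound 1, with a 23-fold lower number from compound 1 to compound 4 (1.37 log units; beyond the scatter) at this position.

Nothing measured here explains these numbers. The compounds shown leave open how a plain pyridine ring without the oxygen would read on this carbon, and whether an amine or a carboxylic acid on the ring would keep the number in this range.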